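A few compounds are considered here, and "the series" means these few. Any claim that something is new, unique, unknown or untested is made for them only; others in the source may bear on it.

The series shares one core, shown in compound 3 `C[C@H](NC(=O)c1c(C2CC2)nnn1Cc1ccc(C(F)(F)F)cc1)c1ccc(C(=O)O)cc1`, and is followed in a functional assay on CHO cells for antagonist activity at prostaglandin E2 receptor EP4 subtype (Homo sapiens), read by calcium flux, with a stated time of 15 min; on this read-out lower numbers stand for stronger inhibition and higher numbers for weaker inhibition. In this assay compound 3 gives 52.1 nM, the lower of the two numbers recorded; compound 2 `C[C@H](NC(=O)c1c(C(F)(F)F)nnn1CCOc1ccc(F)cc1)c1ccc(C(=O)O)cc1`, which gives 276 nM, stands nearest to it and beyond the scatter. Compound 1 `CCCc1c(C(=O)N[C@@H](C)c2ccc(C(=O)O)cc2)nnn1Cc1ccc(C(F)(F)F)cc1` returns only a limit of the assay, > 10000 nM, and so offers no number. The step to compound 4 `Cc1ccc(-c2nnn(Cc3ccc(C(F)(F)F)cc3)c2C(=O)N[C@@H](C)c2ccc(C(=O)O)cc2)s1` is 5-methylthiophen-2-yl in place of cyclopropyl on an aromatic carbon, in words 5-methylthiophen-2-yl in place of cyclopropyl on an aromatic carbon. Among the compounds with values here, no measured pair in this set makes a change of this kind, and the single other variation at the same place is the propyl of compound 1, which sits at the limit of > 10000 nM in this assay, at which 1 of the 3 values shown sits. The reviewer therefore expects a modest step, a 2.1-fold higher number from compound 3 to compound 4 (0.32 log units; beyond the scatter), towards a higher number, close to the edge of the scatter. Compound 4 is estimated at 110 nM, with a range from 25 nM to 600 nM.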

Compound 4, half-maximal inhibitory concentration: 4.6 nM
Compound 4: middle estimate off by 24-fold (1.38 log units), on the high side; the measured number lies below the stated range.
By their numbers in this assay, from the lowest: compound 4; then compound 3; then compound 2. At a limit, above all of these: compound 1.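

Putting 5-methylthiophen-2-yl in place of cyclopropyl gives an 11-fold lower number from compound 3 to compound 4 (1.05 log units; beyond the scatter) in this assay. The group entering has 6 heavy atoms where the one leaving had 3, and the number falls, so this aromatic carbon of the five-membered ring with 3 nitrogen accepts a larger aromatic ring and does not demand a small carbon group. Compound 1, with propyl at the same place, returns only a limit of the assay: the limit of > 10000 nM in this assay, at which 1 of the 4 values shown sits.

The compounds shown leave open whether the gain belongs to the aromatic ring, to its sulfur or to its methyl, which a plain thiophen-2-yl or a phenyl at this place would help to separate. They also leave open how this place would respond to a ring bearing an amine or a longer chain.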